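A Propyl Group Added to a Weak Growth Inhibitor

The source may report more compounds than this note shows. Statements on the series, on what has been measured and on what is new or still open speak of the compounds shown alone.

In a functional assay on NCI-H460 cells (Homo sapiens) for inhibition, read by sulforhodamine B assay, with a stated time of 48 h (a higher number here means a weaker inhibitor of growth, a lower number a stronger inhibitor of growth), compound 1 (`COc1cc(OC)c(OC)cc1/C=C/C(=O)c1ccc(O)cc1O`) gives 60000 nM, the higher of the two numbers available, which makes it the weaker growth inhibitor of the pair. Compound 2 (`CCCc1c(O)ccc(C(=O)/C=C/c2cc(OC)c(OC)c(OC)c2)c1O`) gives 8300 nM, and the gap between them lies beyond the usual scatter. These two compounds differ in more than one place, so their gap does not isolate any single change.

Compound 3 (`CCCc1c(O)ccc(C(=O)/C=C/c2cc(OC)c(OC)cc2OC)c1O`) has not yet been measured in this assay. It departs from compound 1 in one place: propyl in place of hydrogen on an aromatic carbon. For the measured compounds named here, no measured pair shows this change alone, so the evidence is thin. Going by the values given here, the only guide is compound 2, which also carries a propyl group and gives 8300 nM. A move toward stronger inhibition is therefore expected, with the estimated size being a 5.0-fold lower number from compound 1 to compound 3 (0.70 log units; beyond the scatter). For compound 3 the estimated value is 12000 nM, with an expected range from 4000 nM to 35000 nM.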

Compound 3, concentration for 50% growth inhibition: 24500 nM
Beside the measured number, compound 3's estimate is 2.0-fold (0.31 log units) below it; the range from low to high includes it.
By their numbers in this assay, from the lowest: compound 2; then compound 3; then compound 1.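

For the compounds shown here, the step of a 2.4-fold lower number from compound 1 to compound 3 (0.39 log units; beyond the scatter) in this assay is the first to isolate one change, propyl in place of hydrogen on an aromatic carbon, ortho to two hydroxy groups, and it lies beyond the scatter. It shows that this position takes the propyl group with a modest gain in growth inhibition rather than a loss, something the gap between compound 1 and compound 2 could not show, as those two differ in more than one place. The data shown offer nothing that explains why the propyl group has this effect.

On these data alone, it remains open whether a longer chain such as hexyl, a smaller group such as methyl, or an amine at the same position would extend this gain, leave it unchanged or reverse it. Also open, as far as these compounds go, is whether the propyl group would bring a step of similar size on the core of compound 2, which carries the same group, or whether the step seen here holds only for the core of compound 1.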